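Amine substituent at compound 2: propyl to 4-ethoxyphenyl

The source may report more compounds than this note shows. Statements on the series, on what has been measured and on what is new or still open speak of the compounds shown alone.

compound 1 `COc1cc(N)c(Cl)cc1NC(=O)C1CCN(Cc2ccc(Cl)cc2)CC1`: in a functional assay on the whole organism for antagonist activity, with Mus musculus as the target (on this read-out lower numbers stand for an effect already at smaller amounts and higher numbers for an effect only at larger amounts of compound), compound 1 gives 1.2 mg/kg.
compound 2 `CCCCN1CCC(C(=O)Nc2cc(Cl)c(N)cc2OC)CC1`: in this assay compound 2 gives > 10 mg/kg, a limit of the assay.
compound 3 `COc1cc(N)c(Cl)cc1NC(=O)C1CCN(Cc2cccc(C#N)c2)CC1`: in this assay compound 3 gives > 4 mg/kg, also a limit.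

Compound 2 stands only at the limit of > 10 mg/kg in this assay, at which 1 of the 3 values shown sits, so no number is known for it. Compound 4 `CCOc1ccc(CN2CCC(C(=O)Nc3cc(Cl)c(N)cc3OC)CC2)cc1` differs from compound 2 in one place: 4-ethoxyphenyl in place of propyl on a saturated chain carbon bound to an amine nitrogen in a ring. The bearing steps are an at least 8.3-fold higher number from compound 1 to compound 2 (0.92 log units; beyond the scatter), where the aryl group was lost, and a step that the two limits leave unreadable from compound 2 to compound 3, which the two limits leave unreadable; an at least 3.3-fold higher number from compound 1 to compound 3 (0.52 log units; beyond the scatter) shows that the choice of aryl also matters. A return to a 4-substituted aryl is therefore expected to lower the number, with an at least 5.0-fold lower number from compound 2 to compound 4 (0.69 log units; beyond the scatter) as the expected step. Compound 4 is estimated at 2 mg/kg, range 0.6 mg/kg to 8 mg/kg.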

Compound 4, dose for half-maximal effect: 6.3 mg/kg
Beside the measured number, compound 4's estimate is 3.2-fold (0.50 log units) below it; the measured number falls inside the stated range.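

At this position 4-ethoxyphenyl gives a measured number where propyl gave only a limit, but with an at least 1.5-fold lower number from compound 2 to compound 4 (0.20 log units; that floor lies within the scatter) in this assay no gain over propyl is established. The group on the aromatic carbon also counts: ethoxy in place of chloro gives a 5.3-fold higher number from compound 1 to compound 4 (0.72 log units; beyond the scatter) on the shared core. The step between the limit of compound 3 and compound 4 cannot be read. Open, from the compounds shown here alone, is how methoxy or an amine on that aromatic carbon compares with chloro and ethoxy, and whether a longer chain in place of propyl gives a measurable number.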